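This account rests on a few compounds, and the source may have more. Where it says the series, first, only, none or still open, it means among the compounds named here.

Measured in a functional assay on MKN-74 cells (Homo sapiens) for antiproliferative activity, with a stated time of 24 h; on this read-out lower numbers stand for stronger inhibition and higher numbers for weaker inhibition:
- compound 1 `NC(=O)c1c(NC(=O)c2ccccc2Cl)sc2c1CCN(Cc1ccccc1)C2`: 14500 nM
- compound 2 `Cc1ccccc1CN1CCc2c(sc(NC(=O)c3ccccc3Cl)c2C(N)=O)C1`: > 50000 nM
- compound 3 `N#Cc1ccccc1CN1CCc2c(sc(NC(=O)c3ccccc3Cl)c2C(N)=O)C1`: 9500 nM

The entry for compound 2, > 50000 nM, is a limit of the assay and not a number. For the measured compounds named here, compound 3 gives 9500 nM, which is one of only two true numbers in the set. The other belongs to compound 1, and a 1.5-fold lower number from compound 1 to compound 3 (0.18 log units; within the scatter) separates them.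

Compound 4 `NC(=O)c1c(NC(=O)c2ccccc2Cl)sc2c1CCN(Cc1ccccc1Cl)C2` is next, carrying chloro in place of cyano on an aromatic carbon, ortho to a large group: chloro in place of cyano on an aromatic carbon. The 2-cyanobenzyl becomes 2-chlorobenzyl, and the shared core is untouched.

Going by the values given here, three measured steps bear on this, all at the same aromatic carbon. Cyano in place of hydrogen gives a 1.5-fold lower number from compound 1 to compound 3 (0.18 log units; within the scatter). Methyl in place of hydrogen gives an at least 3.4-fold higher number from compound 1 to compound 2 (0.53 log units; beyond the scatter). Cyano in place of methyl gives an at least 5.2-fold lower number from compound 2 to compound 3 (0.72 log units; beyond the scatter). So this carbon tolerates one substituent and not the other, and no chloro analogue has been measured. Compound 4 could follow compound 3 or drift towards compound 2, so a small move to a higher number is expected in this assay, with the range stretched upward.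

The expected change is a 1.6-fold higher number from compound 3 to compound 4 (0.20 log units; within the scatter).

For compound 4 the estimated value is 15000 nM, with an expected range of 6000 nM to 45000 nM.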

Compound 4, half-maximal inhibitory concentration: 4430 nM
The estimate for compound 4 lay 3.4-fold (0.53 log units) above the measured number; the whole stated range lies above it.
By their numbers in this assay, from the lowest: compound 4; then compounds 3 and 1 (each within the scatter of the next). At a limit, above all of these: compound 2.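

In this assay chloro on this aromatic carbon is the only one of the three substituents shown that gives a number clearly below that of the unsubstituted benzyl (a 3.3-fold lower number from compound 1 to compound 4 (0.51 log units; beyond the scatter)), whereas cyano stays within the scatter of hydrogen. The 2-cyanobenzyl to 2-chlorobenzyl change is therefore not neutral (a 2.1-fold lower number from compound 3 to compound 4 (0.33 log units; beyond the scatter)), and with its steps to compounds 1 and 3 beyond the scatter, compound 4 holds the lowest number of the set, so this carbon discriminates among substituents more finely than the earlier comparison of cyano with methyl could show. The step from methyl is large but open-ended (an at least 11-fold lower number from compound 2 to compound 4 (1.05 log units; beyond the scatter)), as the entry for compound 2 is a limit and not a number: the limit of > 50000 nM in this assay, at which 1 of the 4 values shown sits.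

The compounds shown leave open whether the lower number is particular to chloro or extends to other groups at this carbon, such as fluoro, bromo, methoxy or an amine. They also leave open whether chloro elsewhere on the same six-membered aromatic ring would give a similar step in this assay on the shared core.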